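The compounds below may be only part of what the source reports. "The series", "measured", "known", "first", "only" and "open" are said of these compounds alone.

Working notes on the series. In a functional assay on MT2 cells (Homo sapiens) for antiproliferative activity, read by MTT assay, with a stated time of 72 h (on this read-out lower numbers stand for stronger inhibition of growth and higher numbers for weaker inhibition of growth), compound 1 (`O=C(COc1ccc2c(=O)cc(-c3ccccc3)oc2c1)Nc1ccc2ccccc2c1`) gives > 10000 nM, which is a limit of the assay and not a number. Compound 2 (`COc1ccc(NC(=O)COc2c(-c3ccccc3)oc3ccccc3c2=O)cc1`) gives > 10000 nM, which is also a limit. The record so far therefore consists of the limit of > 10000 nM in this assay, at which 2 of the 2 values shown sit, and compound 1 can be placed only by its limit. Within the data shown here, no step between measured compounds is available to size a structural change.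

Compound 3 (`COc1ccc(NC(=O)COc2ccc3c(=O)cc(-c4ccccc4)oc3c2)cc1`) keeps the core of compound 1 and differs on an amide-type nitrogen, with 4-methoxyphenyl in place of naphthalen-2-yl on an amide-type nitrogen. With compound 1 at > 10000 nM, a limit, no clear gain in this assay is expected from this exchange. No step beyond the usual scatter is expected in either direction, and the most likely outcome is another limit rather than a number.

The expected step is a step that the limit leaves unreadable from compound 1 to compound 3. Compound 3 is estimated at 15000 nM, with an expected range of 6000 nM to 40000 nM.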

Compound 3, concentration for 50% growth inhibition: 6700 nM
Estimate against measurement, compound 3: 2.2-fold (0.35 log units) above; measured number inside the range.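

Among these compounds, compound 3 gives the first actual number of the series in this assay, 6700 nM, which shows that a compound with the core of compound 1 can register a value when the group on the amide-type nitrogen is 4-methoxyphenyl. Exchanging naphthalen-2-yl for 4-methoxyphenyl at this place gives an at least 1.4-fold lower number from compound 1 to compound 3 (0.17 log units; that floor lies within the scatter); this figure is only a floor, so the printed step neither establishes a gain beyond the usual scatter nor excludes a larger one. The true size of the change stays unknown because compound 1 is held only by a limit and not by a number: the limit of > 10000 nM in this assay, at which 2 of the 3 values shown sit.

The compounds shown do not separate the effect of the methoxy group from that of going from two aromatic rings to one, and a plain phenyl on the same nitrogen would be the direct test of that. Going by these compounds, it also stays open how far this place tolerates other kinds of group, such as a benzyl, a phenyl carrying an amine or a carboxylic acid, or a short alkyl chain.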